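A few compounds are considered here, and "the series" means these few. Any claim that something is new, unique, unknown or untested is made for them only; others in the source may bear on it.

Three compounds have been measured in an assay on isolated protein for binding affinity to P2Y purinoceptor 1 (Homo sapiens); a higher number here means a weaker inhibitor, a lower number a stronger inhibitor:

Compound 1 `COC(=O)C1(c2ccc(NC(=O)Nc3cccnc3Oc3ccccc3C(C)(C)C)cc2)CC1`: 7 nM
Compound 2 `CC(C)(C)c1ccccc1Oc1ncccc1NC(=O)Nc1ccc(-c2ccccc2CO)cc1F`: 54 nM
Compound 3 `CN(C)CC(C)(C)COc1ccc(NC(=O)Nc2cccnc2Oc2ccccc2[Si](C)(C)C)cc1`: 163 nM

Compound 1 has the lowest number of the three in this assay; compound 2 lies higher by a margin beyond the scatter, and compound 3 lies higher still, also beyond the scatter. Compound 4 `CC(C)CN1CCC(COc2ccc(NC(=O)Nc3cccnc3Oc3ccccc3C(C)(C)C)cc2)CC1` is not yet measured. It differs from compound 1 in one place: (1-isobutylpiperidin-4-yl)methoxy in place of 1-(methoxycarbonyl)cyclopropyl on an aromatic carbon. Among the measured compounds shown here, no measured pair shows this change by itself, so the step can only be guessed. Compound 3, which carries a basic amine on its alkoxy chain and gives 163 nM, hints that the direction is toward a higher number, though compound 3 differs elsewhere as well. Compound 4 is therefore expected to sit somewhat above compound 1, a step of a 4.3-fold higher number from compound 1 to compound 4 (0.63 log units; beyond the scatter), likely near the edge of the scatter. The estimate for compound 4 is 30 nM, within 6 nM to 150 nM.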

Compound 4, inhibition constant in the P2Y purinoceptor 1 assay: 87 nM
Beside the measured number, compound 4's estimate is 2.9-fold (0.46 log units) below it; the range from low to high includes it.
By their numbers in the P2Y purinoceptor 1 assay, from the lowest: compound 1; then compounds 2, 4 and 3 (each within the scatter of the next, the first and the last beyond it).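

In the P2Y purinoceptor 1 assay the exchange of 1-(methoxycarbonyl)cyclopropyl for (1-isobutylpiperidin-4-yl)methoxy on this aromatic carbon gives a 12-fold higher number from compound 1 to compound 4 (1.09 log units; beyond the scatter). Among the compounds shown here, this is the first direct reading at this position, and it shows that the position responds strongly to this change. In a physicochemical assay for lipophilicity, read by HPLC (on this read-out higher numbers stand for higher lipophilicity and lower numbers for lower lipophilicity), compound 1 gives 5.1 and compound 4 gives 4.5. The loss of binding comes with lower rather than higher lipophilicity: the measured partition coefficient of compound 1, 5.1, and of compound 4, 4.5, a number 0.60 log units lower (beyond the scatter).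

The whole group changes at once, so the roles of the ester, the three-membered ring and the piperidine nitrogen remain unseparated. A carboxylic acid in place of the methyl ester, or a piperidine without the isobutyl group, would test single parts.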